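The source may report more compounds than this note shows. Statements on the series, on what has been measured and on what is new or still open speak of the compounds shown alone.

Measured compounds and their values:

Compound 1 `Nc1ccccc1NC(=O)c1ccc(CSC(=S)N2CCc3cc(Cl)ccc32)cc1` gives 31.9% in a functional assay on A-375 cells (Homo sapiens) for antiproliferative activity, read by CCK-8 assay, with a stated time of 72 h, tested at 2 uM; on this read-out higher numbers stand for a stronger effect at the one concentration tested and lower numbers for a weaker effect.
Compound 2 `CC1CCCCN1C(=S)SCc1ccc(C(=O)Nc2ccccc2N)cc1` gives 42.5% in this assay.
Compound 3 `CC1CCN(C(=S)SCc2ccc(C(=O)Nc3ccccc3N)cc2)CC1` gives 32.7% in this assay.

All three share the same core and differ only in the ring attached to the thiocarbonyl carbon. Compound 3 stands second highest of the three numbers; its nearest neighbour is compound 1 a number 0.8 percentage points higher from compound 1 to compound 3 (within the scatter), and the remaining step of a number 9.8 percentage points lower from compound 2 to compound 3 (within the scatter) is also within the scatter. Going by the values given here, only the step from compound 1 to compound 2 a number 10.6 percentage points higher from compound 1 to compound 2 (beyond the scatter) reaches beyond the scatter, and modestly so.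

Compound 4 `Nc1ccccc1NC(=O)c1ccc(CSC(=S)N2CCCC2)cc1` is not yet measured. It differs from compound 3 in one place: pyrrolidin-1-yl in place of 4-methylpiperidin-1-yl on a thiocarbonyl carbon. The closest guide is the step from compound 2 to compound 3 a number 9.8 percentage points lower from compound 2 to compound 3 (within the scatter), where one saturated nitrogen ring replaced another without moving the number beyond the scatter; the step from compound 1 to compound 3 a number 0.8 percentage points higher from compound 1 to compound 3 (within the scatter) tells the same. Nothing measured involves pyrrolidin-1-yl itself. A step within the scatter is therefore expected in this assay, with no clear direction. Compound 4 is estimated at 33%, between 20% and 48%, an expected step of a number 0.3 percentage points higher from compound 3 to compound 4 (within the scatter).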

Compound 4, a percentage reported as inhibition, at one concentration (the size of the read-out at that concentration, not a potency): 30.2%
Compound 4: the middle estimate sits 2.8 percentage points above what was measured; low and high end bracket the measured number.
By their numbers in this assay, from the lowest: compounds 4, 1, 3 and 2 (each within the scatter of the next, the first and the last beyond it).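

In this assay, going from a six-membered ring carrying a methyl to the plain five-membered ring of pyrrolidin-1-yl on the thiocarbonyl carbon gives a number 2.5 percentage points lower from compound 3 to compound 4 (within the scatter) and so does not clearly change the read-out. The comparison with the larger chlorine-bearing group gives a number 1.7 percentage points lower from compound 1 to compound 4 (within the scatter) as well, so three quite different rings now read alike, while the step to pyrrolidin-1-yl from 2-methylpiperidin-1-yl gives a number 12.3 percentage points lower from compound 2 to compound 4 (beyond the scatter) and is the second step beyond the scatter that sets compound 2 apart, though compound 2 remains within the scatter of compound 3. No measurement is available that could explain these numbers.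

Piperidin-1-yl without any methyl, morpholin-4-yl with an oxygen in its ring, and open-chain diethylamino on the same thiocarbonyl carbon would show whether the higher number of compound 2 belongs to that methyl placement or to something broader, and this remains open. On these data alone, all of these numbers also come from one concentration, so how the compounds compare in potency remains open too.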